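Hydroxy added to compound 1: expected effect on growth

A few compounds are considered here, and "the series" means these few. Any claim that something is new, unique, unknown or untested is made for them only; others in the source may bear on it.

Going by the values given here, in a functional assay on K562 cells (Homo sapiens) for inhibition (on this read-out higher numbers stand for weaker inhibition of growth and lower numbers for stronger inhibition of growth), compound 1 (`COc1ccc(-n2cnnc2-c2cc(OC)c(OC)c(OC)c2)cc1`) gives 631 nM as the higher of the two numbers so far, and compound 2 (`COc1cc(-c2nncn2-c2ccc(N(C)C)cc2)cc(OC)c1OC`) gives 12.9 nM as the lower. Compound 3 (`COc1ccc(-n2cnnc2-c2cc(OC)c(OC)c(OC)c2)cc1O`) keeps the methoxy group of compound 1 and carries one new group, ortho to that methoxy: hydroxy in place of hydrogen on an aromatic carbon. Among the compounds with values here, only one measured step bears on this, and it is a large one: a 49-fold lower number from compound 1 to compound 2 (1.69 log units; beyond the scatter) for dimethylamino in place of methoxy on an aromatic carbon. That is a different change at a different carbon, so it sets no size here and shows only that a single substitution can move this read-out well beyond the scatter. The expected step, an uncertain move toward a lower number, is a 6.3-fold lower number from compound 1 to compound 3 (0.80 log units; beyond the scatter) in this assay by estimate. For compound 3 the estimated value is 100 nM within an expected range of 15 nM to 600 nM in this series.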

Compound 3, concentration for 50% growth inhibition: 209 nM
For compound 3 the middle estimate is 2.1-fold (0.32 log units) below the measured one, and the stated range covers the measured number.
By their numbers in this assay, from the lowest: compound 2; then compound 3; then compound 1.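

In this assay, hydroxy in place of hydrogen on the aromatic carbon ortho to the methoxy group gives a 3.0-fold lower number from compound 1 to compound 3 (0.48 log units; beyond the scatter), a modest step beyond the scatter. The earlier step, a 49-fold lower number from compound 1 to compound 2 (1.69 log units; beyond the scatter), came from replacing the methoxy group itself; this one shows that the number can also fall with the methoxy group kept and a new group added on another carbon of the same ring. Nothing available explains the size or direction of this step.

As far as these compounds go, whether this step is specific to hydroxy remains open, and an amine, fluorine or a second methoxy group on the same carbon would test that. Also open, from the compounds shown here alone, is whether the hydroxy and dimethylamino changes add up when both stand on one ring.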